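This account rests on a few compounds, and the source may have more. Where it says the series, first, only, none or still open, it means among the compounds named here.

Measured compounds in a functional assay on cells for agonist activity at Free fatty acid receptor 1 (Rattus norvegicus), read by FLIPR and calcium flux; a lower number here means that less compound is needed, a higher number that more compound is needed for the effect:
compound 1, `CC#C[C@@H](Cc1nnn[nH]1)c1ccc(OCc2ccc3scc(-c4cncnc4C)c3c2)cc1`, gives 18 nM;
compound 2, `CC#C[C@@H](Cc1nnn[nH]1)c1ccc(OCc2ccc3scc(-c4ccc(OCCOC)cc4C)c3c2)cc1`, gives 4 nM;
compound 3, `CC#C[C@@H](Cc1nnn[nH]1)c1ccc(OCc2ccc3sc(F)c(-c4ccc(OCCOC)cc4C)c3c2)cc1`, gives 24 nM.

Compound 2 stands lowest of the three numbers in this assay. Its nearest neighbour is compound 1, reached by a 4.5-fold lower number from compound 1 to compound 2 (0.65 log units; beyond the scatter), and its furthest is compound 3, reached by a 6.0-fold higher number from compound 2 to compound 3 (0.78 log units; beyond the scatter). Both steps lie beyond the scatter, so compound 2 is the most potent of the three measured compounds.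

Compound 4, `CC#C[C@@H](Cc1nnn[nH]1)c1ccc(OCc2ccc3scc(-c4ccc(OCCC(C)(C)O)cc4C)c3c2)cc1`, differs from compound 2 in one place: 1-hydroxy-1-methylethyl in place of methoxy on a saturated chain carbon, two bonds along the chain from an oxygen on an aromatic ring. Read one bond further out, the change is 2-methoxyethoxy to 3-hydroxy-3-methylbutoxy.

Neither measured step speaks directly to this change. Among the measured compounds shown here, the step from compound 1 to compound 2 exchanges the whole aryl group, and the step from compound 2 to compound 3 introduces a fluoro on an aromatic carbon; nothing among the measured compounds varies the chain carrying the methoxy. The two measured steps are modest, so there is no ground to expect a large move in either direction, and a step within or near the scatter seems the most reasonable expectation.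

Compound 4 is therefore estimated to give 6 nM in this assay, within a range of 2 nM to 18 nM, that is, an expected step of a 1.5-fold higher number from compound 2 to compound 4 (0.18 log units; within the scatter).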

Compound 4, half-maximal effective concentration: 4 nM
Beside the measured number, compound 4's estimate is 1.5-fold (0.18 log units) above it, and the stated range covers the measured number.
By their numbers in this assay, from the lowest: compounds 2 and 4 (each within the scatter of the next); then compounds 1 and 3 (each within the scatter of the next).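

In this assay, replacing methoxy with 1-hydroxy-1-methylethyl on the saturated chain carbon, which turns 2-methoxyethoxy into 3-hydroxy-3-methylbutoxy, gives no change at the digits printed from compound 2 to compound 4 (within the scatter). Among the compounds shown here, this is the first view of the chain itself: the earlier steps exchanged the whole aryl group or added a fluoro on an aromatic carbon and moved the number beyond the scatter, whereas here a group with more heavy atoms and a hydrogen-bond donor, which methoxy lacks, leaves the number within the scatter. No measurement bearing on why the number holds is available.

The change alters the end group and the chain length together, so the compounds shown cannot separate the two, and they leave open whether an amine or a carboxylic acid at the end of this chain, or a still longer chain, would also hold the number. They also leave open whether the fluoro, which gave a 6.0-fold higher number from compound 2 to compound 3 (0.78 log units; beyond the scatter), would move the number in the same way when added to compound 4.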